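Alkyl variation on the ring nitrogen of compound 3

The source may report more compounds than this note shows. Statements on the series, on what has been measured and on what is new or still open speak of the compounds shown alone.

Compound 1 `CN1CCN(c2nc3ccccc3[nH]2)CC1` carries hydrogen on the aromatic nitrogen of the shared core. In a functional assay on ileum for inhibition of histamine H1 receptor (Cavia porcellus) (a higher number here means a weaker inhibitor, a lower number a stronger inhibitor), compound 1 gives > 3000 nM, which is a limit of the assay rather than a number (the limit of > 3000 nM in this assay, at which 1 of the 3 values shown sits). Compound 2 `CCCn1c(N2CCN(C)CC2)nc2ccccc21` carries propyl on that nitrogen, and in this assay compound 2 gives 380 nM. Compound 3 `CCCCOCCn1c(N2CCN(C)CC2)nc2ccccc21` carries 2-butoxyethyl, and in this assay compound 3 gives 38 nM, the lowest of the two numbers in the series; compound 2 is its nearest neighbour. The measured steps run an at least 7.8-fold lower number from compound 1 to compound 2 (0.89 log units; beyond the scatter), an at least 78-fold lower number from compound 1 to compound 3 (1.89 log units; beyond the scatter) and a 10-fold lower number from compound 2 to compound 3 (1.00 log units; beyond the scatter).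

Compound 4 `CCCC(C)n1c(N2CCN(C)CC2)nc2ccccc21` is not yet measured. 1-methylbutyl in place of 2-butoxyethyl on an aromatic nitrogen Two measured steps bear on it. The step of a 10-fold lower number from compound 2 to compound 3 (1.00 log units; beyond the scatter) shows that butoxy in place of methyl on the chain gave a lower number, and compound 4 gives up that butoxy while keeping a chain of carbon only. The step of an at least 7.8-fold lower number from compound 1 to compound 2 (0.89 log units; beyond the scatter) shows that any alkyl on the aromatic nitrogen already lowers the number well past the limit of compound 1. Compound 4 is therefore expected to sit between compound 2 and compound 3, a rise a 3.9-fold higher number from compound 3 to compound 4 (0.60 log units; beyond the scatter) in this assay. The estimate for compound 4 is 150 nM, with a range from 50 nM to 500 nM.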

Compound 4, half-maximal inhibitory concentration: 1400 nM
Compound 4: middle estimate off by 9.3-fold (0.97 log units), on the low side; measured number outside the range, above it.
By their numbers in this assay, from the lowest: compound 3; then compound 2; then compound 4. At a limit, above all of these: compound 1.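

In this assay, the change from 2-butoxyethyl to 1-methylbutyl on the aromatic nitrogen gives a 37-fold higher number from compound 3 to compound 4 (1.57 log units; beyond the scatter), so this position responds strongly to which chain it carries, and compound 4 does not fall on the path from compound 2 to compound 3. The all-carbon 1-methylbutyl also stands above propyl, with a 3.7-fold higher number from compound 2 to compound 4 (0.57 log units; beyond the scatter), so among the compounds shown, adding carbon to the group on this nitrogen does not lower the number; the only group here that goes with a lower number than propyl is the oxygen-bearing 2-butoxyethyl of compound 3. The step of an at least 2.1-fold lower number from compound 1 to compound 4 (0.33 log units; beyond the scatter) shows that compound 4 keeps only a small margin over the hydrogen of compound 1, and this step is read against a limit rather than a number: the limit of > 3000 nM in this assay, at which 1 of the 4 values shown sits.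

1-methylbutyl differs from 2-butoxyethyl in its branch as well as in its oxygen, so these compounds cannot separate the two changes, and a straight pentyl chain would bear on that question. On these data alone, it also remains open whether the ether oxygen itself matters or whether a chain ending in an amine or a hydroxyl group would serve in its place.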